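Series notes: aryl amine variation on the shared core

The source may hold more compounds than are shown below. What is called first, only, known or untested is meant among the compounds shown, and "the series" means these compounds.

Compound 1, `NC(=O)c1nn(-c2ccc3onc(N)c3c2)c2c(F)c(-c3ccc(N4CCCCC4=O)cc3F)ccc12`, in an assay on isolated protein for inhibition of Trypsin (Homo sapiens) (a higher number here means a weaker inhibitor, a lower number a stronger inhibitor), gives > 10000 nM, which is a limit of the assay and not a number.
Compound 2, `CN(C)Cc1[nH]ncc1-c1ccc(-c2ccc3c(C(N)=O)nn(-c4ccc5onc(N)c5c4)c3c2F)c(F)c1`, gives in this assay > 10000 nM, also a limit.
Compound 3, `CN(C)CCN(c1ccccc1)c1ccc(-c2ccc3c(C(N)=O)nn(-c4ccc5onc(N)c5c4)c3c2F)c(F)c1`, gives in this assay > 10000 nM, again a limit.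

Compound 3 thus stands at the limit together with the other two members of the series; since none of the three values is a number, no order among them can be read. The steps a step that the two limits leave unreadable from compound 1 to compound 3 and a step that the two limits leave unreadable from compound 2 to compound 3 remain unreadable, as does a step that the two limits leave unreadable from compound 1 to compound 2; all three values sit at the limit of > 10000 nM in this assay, at which 3 of the 3 values shown sit.

Compound 4, `CN(C)CCN(c1cccnc1)c1ccc(-c2ccc3c(C(N)=O)nn(-c4ccc5onc(N)c5c4)c3c2F)c(F)c1`, differs from compound 3 by pyridin-3-yl in place of phenyl on a nitrogen on an aromatic ring. Among the compounds with values here, no measured step bears directly on this change: the steps measured so far all join limits, have no readable size, and concern exchanges of other groups on the aromatic carbon. Nothing in the data points to a change beyond the scatter, and the three limits make a readable number for compound 4 unlikely. The step from compound 3 to compound 4 is expected to be a step that the limit leaves unreadable from compound 3 to compound 4, that is, none beyond the scatter. For compound 4 an inhibition constant of 20000 nM is estimated, with a range from 5000 nM to 100000 nM, most probably reported again only as a limit.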

Compound 4, inhibition constant: > 10000 nM
Compound 4: a limit, no number; the forecaster's own chance of this, stated with the estimate: 85%; the middle value is on the limit's open side.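

Within the data shown here, compound 4 gives > 10000 nM in this assay and this is again a limit, not a number; no step from compound 1, compound 2 or compound 3 to compound 4 can be read: the limit of > 10000 nM in this assay, at which 4 of the 4 values shown sit. The compounds shown leave open how pyridin-3-yl and phenyl on that nitrogen compare, and whether any change to the shared core gives a readable inhibition constant.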